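This account rests on a few compounds, and the source may have more. Where it says the series, first, only, none or still open, it means among the compounds named here.

Working notes on the ester series. Compound 1 `CC(=O)OCCc1ccc(O)c(O)c1` gives 100 ug/mL in an ADME assay on Vero cells (Chlorocebus sabaeus) for cytotoxicity, read by MTT assay, with a stated time of 24 h; on this read-out higher numbers stand for lower toxicity in this test and lower numbers for higher toxicity in this test. Compound 2 `CCC(=O)OCCc1ccc(O)c(O)c1` gives 40 ug/mL in this assay, and compound 3 `CCCC(=O)OCCc1ccc(O)c(O)c1` gives 100 ug/mL in this assay. Compound 3 thus sits level with compound 1, the two together the highest of the three numbers, with compound 2 the furthest from it. Compound 4 `CCCCC(=O)OCCc1ccc(O)c(O)c1` differs from compound 3 by methyl in place of hydrogen on a saturated chain carbon, three bonds along the chain from a carbonyl carbon. Within the data shown here, the steps that bear on this change are a 2.5-fold lower number from compound 1 to compound 2 (0.40 log units; beyond the scatter), no change at the digits printed from compound 1 to compound 3 (within the scatter) and a 2.5-fold higher number from compound 2 to compound 3 (0.40 log units; beyond the scatter): lengthening the chain has given no consistent direction so far, compound 2 being the only departure. For compound 4 no step beyond the scatter is therefore expected in this assay, no change at the digits printed from compound 3 to compound 4 (within the scatter). Compound 4 is estimated at 100 ug/mL, range 40 ug/mL to 200 ug/mL.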

Compound 4, half-maximal cytotoxic concentration: 25 ug/mL
The estimate for compound 4 lay 4.0-fold (0.60 log units) above the measured number; measured number outside the range, below it.
By their numbers in this assay, from the lowest: compounds 4 and 2 (each within the scatter of the next); then compounds 1 and 3 (each within the scatter of the next).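

In this assay, methyl in place of hydrogen three bonds along the chain from a carbonyl carbon gives a 4.0-fold lower number from compound 3 to compound 4 (0.60 log units; beyond the scatter), so compound 2 is no longer the only departure, and the longest chain shown gives a 4.0-fold lower number from compound 1 to compound 4 (0.60 log units; beyond the scatter). Compound 4 is not separated from compound 2, with a 1.6-fold lower number from compound 2 to compound 4 (0.20 log units; within the scatter). The rise at compound 3 goes against any steady fall with chain length, yet the step from compound 3 matches the one from compound 1 in size: the same change on two cores in this assay, a 2.5-fold lower number (0.40 log units; beyond the scatter) from compound 1 to compound 2 and a 4.0-fold lower number (0.60 log units; beyond the scatter) from compound 3 to compound 4, 1.6-fold (0.20 log units) apart, within the scatter of two such steps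

As far as these compounds go, whether a pentyl or hexyl chain would continue these ups and downs or settle remains open. So does the effect of a branched isopropyl group at the same carbonyl.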